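The source may report more compounds than this note shows. Statements on the series, on what has been measured and on what is new or still open speak of the compounds shown alone.

In an assay on cells for binding affinity to Myc proto-oncogene protein (Homo sapiens) (a lower number here means a stronger inhibitor, a higher number a weaker inhibitor), compound 2 `Cn1nncc1-c1cc(-c2ccc(C(N)=O)cc2)cc(-c2ccc(C#N)cc2)n1` gives 40000 nM, the highest of the two numbers in hand; compound 1 `N#Cc1ccc(-c2cc(-c3ccc(C(N)=O)cc3)cc(-c3ccco3)n2)cc1` gives 3000 nM, the nearest value. Compound 3 `N#Cc1ccc(-c2cc(-c3ccc(C(N)=O)cc3)cc(-c3cccc(F)c3)n2)cc1` differs from compound 2 by 3-fluorophenyl in place of 1-methyl-1H-1,2,3-triazol-5-yl on an aromatic carbon. Of the measured steps only a 13-fold higher number from compound 1 to compound 2 (1.12 log units; beyond the scatter) bears on this position, and it shows that a five-membered aromatic ring there gives a large shift in this assay. Replacing the triazole with a six-membered carbon-only ring is therefore expected to move the number back toward compound 1, by a 10-fold lower number from compound 2 to compound 3 (1.00 log units; beyond the scatter). Compound 3 is estimated at 4000 nM, in the range 1500 nM to 12000 nM.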

Compound 3, half-maximal inhibitory concentration in the Myc proto-oncogene protein assay: > 100000 nM
Compound 3: a limit, no number (the forecaster's own chance of this, stated with the estimate: 5%); at least 25-fold (1.39 log units) between middle value and limit.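

In the Myc proto-oncogene protein assay compound 3 gives > 100000 nM, which is a limit of the assay and not a number. In the Myc proto-oncogene protein assay the steps are an at least 2.5-fold higher number from compound 2 to compound 3 (0.39 log units; beyond the scatter) and an at least 33-fold higher number from compound 1 to compound 3 (1.52 log units; beyond the scatter), so at this place next to the ring nitrogen the order runs furan-2-yl, then 1-methyl-1H-1,2,3-triazol-5-yl, then 3-fluorophenyl, and a six-membered carbon-only ring does not restore the number of compound 1. In a physicochemical assay for solubility, at pH 6 (a lower number here means a less soluble compound, a higher number a more soluble compound), compound 2 gives 32000 nM and compound 3 gives 2000 nM. The same change also costs solubility in the physicochemical assay: the measured solubility of compound 2, 32000 nM, and of compound 3, 2000 nM, a 16-fold lower number (1.20 log units; beyond the scatter)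

Open, going by these compounds, is whether the six-membered ring or its fluorine goes with the weaker number. A plain phenyl or a pyridine ring at this place would separate the two.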